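Selenium-to-sulfur swap on the shared core

A few compounds are considered here, and "the series" means these few. Any claim that something is new, unique, unknown or untested is made for them only; others in the source may bear on it.

Compound 1 `C[Se]/C(=N\C(=O)c1cc2ccccc2s1)NC(=O)c1cc2ccccc2s1`: 490 nM
Compound 2 `C[Se]/C(=N\C(=O)c1ccco1)NC(=O)c1ccco1`: 5940 nM
Compound 3 `C[Se]/C(=N\C(=O)c1sccc1Cl)NC(=O)c1sccc1Cl`: 3160 nM

In an ADME assay on MCF-10A cells (Homo sapiens) for cytotoxicity, read by MTT assay, with a stated time of 72 h (on this read-out lower numbers stand for stronger inhibition of growth and higher numbers for weaker inhibition of growth), compound 3 stands second highest of the three numbers: its gap to compound 2 is within the scatter, while compound 1 sits at a lower number, beyond the scatter. Compound 4 `CS/C(=N\C(=O)c1sccc1Cl)NC(=O)c1sccc1Cl` differs from compound 3 by a group of 2 heavy atoms (1 carbon, 1 sulfur; no ring) in place of a group of 2 heavy atoms (1 carbon, 1 selenium; no ring), on a carbon with a double bond to nitrogen. For the measured compounds named here, no measured pair carries this change, so the three numbers give no size for it. The expected step of a 1.3-fold higher number from compound 3 to compound 4 (0.10 log units; within the scatter) is none beyond the scatter, with the middle of the expectation set a little toward a higher number. Compound 4 is estimated at 4000 nM, in a range from 1500 nM to 12000 nM.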

Compound 4, concentration for 50% growth inhibition: 90 nM
The estimate for compound 4 lay 44-fold (1.65 log units) above the measured number; the measured number lies below the stated range.
By their numbers in this assay, from the lowest: compound 4; then compound 1; then compounds 3 and 2 (each within the scatter of the next).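

In this assay, methylsulfanyl in place of the group of carbon and selenium, on a carbon with a double bond to nitrogen, gives a 35-fold lower number from compound 3 to compound 4 (1.55 log units; beyond the scatter) with the rest of the molecule unchanged. This position is therefore highly sensitive to the change, in a way that the three selenium compounds could not show. Nothing at hand accounts for the size of this step.

From the compounds shown here alone, whether the same change gives a step of similar size with the amide groups of compound 1 or compound 2 remains open. Also open, going by these compounds, is how a longer sulfur chain, such as ethylsulfanyl, or an amine would read on this carbon.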